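Swapping 4-Iodophenyl for 3-Fluorophenyl on the Amine Nitrogen

The source may hold more compounds than are shown below. What is called first, only, known or untested is meant among the compounds shown, and "the series" means these compounds.

Among the compounds with values here, compound 1 `O=C1C(Nc2ccc(I)cc2)=CC(=O)c2c1nc1n2[C@H]2OC[C@@H](O)[C@H]2OC1` is the only one of three related compounds that gives a number in a functional assay on MGC-803 cells (Homo sapiens) for inhibition, read by sulforhodamine B assay; a higher number here means a weaker inhibitor, a lower number a stronger inhibitor; there compound 1 gives 2150 nM. Compound 2 `CCCN(CCC)C1=CC(=O)c2nc3n(c2C1=O)[C@H]1OC[C@@H](O)[C@H]1OC3` reaches only a limit of the assay, > 16000 nM. Compound 3 `O=C1C=C(N2CCCCC2)C(=O)c2c1nc1n2[C@H]2OC[C@@H](O)[C@H]2OC1` likewise stops at a limit, > 8000 nM. Within the data shown here, the single step measured between neighbours, a step that the two limits leave unreadable from compound 2 to compound 3, joins two such limits and its size cannot be read because the limit of > 16000 nM in this assay, at which 1 of the 3 values shown sits, and the limit of > 8000 nM in this assay, at which 1 of the 3 values shown sits, bound it from both sides.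

Compound 4 `O=C1C(Nc2cccc(F)c2)=CC(=O)c2c1nc1n2[C@H]2OC[C@@H](O)[C@H]2OC1` differs from compound 1 in one place: 3-fluorophenyl in place of 4-iodophenyl on an amine nitrogen. Among the measured compounds shown here, the one measured step concerns a dipropylamino and a piperidin-1-yl group on a double-bonded ring carbon, not an aryl group on the amine nitrogen, and it is unreadable in any case, so no measured step bears on this change. The halogenated phenyl ring keeps its size and ring count, and its donors and acceptors are unchanged; the expectation is therefore a step near the scatter, with a slight lean towards weaker inhibition and a wide range. Compound 4 is expected to give about 3500 nM, between 1200 nM and 12000 nM. The estimated step of a 1.6-fold higher number from compound 1 to compound 4 (0.21 log units; within the scatter) is expected to stay close to the scatter.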

Compound 4, half-maximal inhibitory concentration: 1470 nM
Compound 4: middle estimate off by 2.4-fold (0.38 log units), on the high side, and the stated range covers the measured number.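

In this assay the change gives a 1.5-fold lower number from compound 1 to compound 4 (0.17 log units; within the scatter), so 3-fluorophenyl and 4-iodophenyl on the amine nitrogen cannot be told apart in this assay. Within the data shown here, this is the first readable step, and the first to concern this position, since the earlier step dealt with a different pair of groups on a double-bonded ring carbon and could not be read. It shows that this position accepts a change of both the halogen and its place on the phenyl ring without a measurable shift in the read-out, although the measurements shown offer no explanation for why the two groups read alike.

Left open is whether the halogen matters at all, and whether an unsubstituted phenyl, a methoxyphenyl, a carboxylic acid on the phenyl ring or a benzyl group on the amine nitrogen would read like these two groups. Among these compounds, compound 2 and compound 3 stand only at limits of the assay, so no step involving them can be read, and how far the aryl group on the amine nitrogen matters remains unsettled.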